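Ester to acid on a second carbamate core

A few compounds are considered here, and "the series" means these few. Any claim that something is new, unique, unknown or untested is made for them only; others in the source may bear on it.

Measured compounds and their values:
- compound 1 `COC(=O)CCCCC[C@H](NC(=O)OCc1ccccc1)C(=O)NC1CCCC1`: 65%
- compound 2 `O=C(O)CCCCC[C@H](NC(=O)OCc1ccccc1)C(=O)NC1CCCC1`: 40%
- compound 3 `COC(=O)CCCCC[C@H](NC(=O)OC(C)(C)C)C(=O)NC1CCCC1`: 60%

All three were tested in an assay on isolated protein for inhibition of protein deacetylase HDAC6 (Homo sapiens), read by fluorescence, tested at 1 uM; a lower number here means less inhibition, a higher number more inhibition at the concentration tested (going by the name of the read-out). Compound 3 differs from compound 1 by tert-butyl in place of benzyl on an oxygen next to a carbonyl group, a change giving a number 5 percentage points lower from compound 1 to compound 3 (within the scatter). Compound 2 differs from compound 1 by hydrogen in place of methyl on an oxygen next to a carbonyl group, which gave a number 25 percentage points lower from compound 1 to compound 2 (beyond the scatter). Compound 4 `CC(C)(C)OC(=O)N[C@@H](CCCCCC(=O)O)C(=O)NC1CCCC1` has not yet been measured; it differs from compound 3 by hydrogen in place of methyl on an oxygen next to a carbonyl group, the same change as from compound 1 to compound 2, made at the same place. Beside that earlier step, the step expected in this assay is a number 23 percentage points lower from compound 3 to compound 4 (beyond the scatter), resting on the single measured instance a number 25 percentage points lower from compound 1 to compound 2 (beyond the scatter) and on compound 3 giving 60%. Compound 4 is therefore estimated at 37%, likely between 20% and 55%.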

Compound 4, a percentage reported as inhibition, at one concentration (the size of the read-out at that concentration, not a potency): 45%
For compound 4 the middle estimate is 8 percentage points below the measured one; the range from low to high includes it.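

In this assay, within the data shown here, going from methoxycarbonyl to carboxy on the core of compound 3 gives a number 15 percentage points lower from compound 3 to compound 4 (beyond the scatter), so this change carries over from the core of compound 1 with no difference that can be told apart: the same change on two cores in this assay, a number 25 percentage points lower (beyond the scatter) from compound 1 to compound 2 and a number 15 percentage points lower (beyond the scatter) from compound 3 to compound 4, 10 percentage points apart, within the scatter of two such steps The step from benzyl to tert-butyl, read on the two acids, is a number 5 percentage points higher from compound 2 to compound 4 (within the scatter), and it agrees with the same step on the two esters: the same change on two cores in this assay, a number 5 percentage points lower (within the scatter) from compound 1 to compound 3 and a number 5 percentage points higher (within the scatter) from compound 2 to compound 4, 10 percentage points apart, within the scatter of two such steps This agreement rests on only two cores that differ in one group, so it does not show that the change would behave alike on other cores.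

The compounds shown leave open what an amide or a hydroxamic acid would give in place of the methoxycarbonyl group. They also leave open what a shorter or longer chain would give.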